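The compounds below may be only part of what the source reports. "The series", "measured", "known", "first", "only" and "open" are said of these compounds alone.

Three compounds built on one shared core were tested in an assay on brain for inhibition of Fatty-acid amide hydrolase 1 (Rattus norvegicus), read by scintillation counting, with a stated time of 10 min; on this read-out higher numbers stand for weaker inhibition and lower numbers for stronger inhibition. Compound 1 `CC(C)Cc1ccc(C(C)C(=O)NCc2cccc(C(F)(F)F)c2)cc1` gives 28000 nM, compound 2 `CC(C)Cc1ccc(C(C)C(=O)NCc2ccccc2Cl)cc1` gives 4100 nM, and compound 3 `CC(C)Cc1ccc(C(C)C(=O)N2CCN(c3ccccc3)CC2)cc1` gives 4700 nM. Compound 3 therefore holds the second highest of the three numbers: its value and that of compound 2 lie within the usual scatter of each other, while compound 1 gives a clearly higher number, beyond the scatter. Compound 4 `COc1ccc(N2CCN(C(=O)C(C)c3ccc(CC(C)C)cc3)CC2)cc1` differs from compound 3 in a single place: methoxy in place of hydrogen on an aromatic carbon. Going by the values given here, no measured pair shows this particular change, so nothing here says how large a step it brings or in which direction. The expected step in this assay is a 1.3-fold lower number from compound 3 to compound 4 (0.13 log units; within the scatter), small enough to stay within the scatter. Compound 4 is thus estimated at 3500 nM, with a likely range from 1000 nM to 12000 nM.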

Compound 4, half-maximal inhibitory concentration: 4500 nM
Estimate against measurement, compound 4: 1.3-fold (0.11 log units) below; measured number inside the range.
By their numbers in this assay, from the lowest: compounds 2, 4 and 3 (each within the scatter of the next); then compound 1.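

Going by these compounds alone, this is the first measured case of this change: with methoxy in place of hydrogen on an aromatic carbon, para to a large group, this assay shows a 1.0-fold lower number from compound 3 to compound 4 (0.02 log units; within the scatter). The phenyl to 4-methoxyphenyl swap therefore leaves the number within the scatter, so this position accepts methoxy with no readable shift. No measurement shown here offers any explanation for this result.
As far as these compounds go, whether this tolerance holds for other groups at this carbon, such as an amine or a carboxylic acid, remains open. So does the effect of methoxy on the ring's other carbons.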